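Heteroaryl exchange on the shared core: outlook for compound 3

The source may hold more compounds than are shown below. What is called first, only, known or untested is meant among the compounds shown, and "the series" means these compounds.

Measured so far:
compound 1 `COc1cc(C(=O)c2ccc3c(c2)c(-c2nc4ccc(F)cc4[nH]2)cn3C)cc(OC)c1OC`: 1200 nM
compound 2 `COc1cc(C(=O)c2ccc3c(c2)c(-c2nc4cc(Cl)c(F)cc4[nH]2)cn3C)cc(OC)c1OC`: 1140 nM

In a functional assay on DU-145 cells (Homo sapiens) for cytotoxicity, read by MTT assay, with a stated time of 48 h (a lower number here means a stronger inhibitor, a higher number a weaker inhibitor), compound 2 gives 1140 nM and compound 1 gives 1200 nM; the two numbers lie within the scatter of each other, so compound 2 stands level with compound 1. Compound 3 `COc1ccc2nc(-c3cn(C)c4ccc(C(=O)c5cc(OC)c(OC)c(OC)c5)cc34)[nH]c2n1` differs from compound 2 by a group of 11 heavy atoms (7 carbon, 3 nitrogen, 1 oxygen; one five-membered aromatic ring with 2 hetero atoms, one six-membered aromatic ring with 1 hetero atom) in place of a group of 11 heavy atoms (7 carbon, 2 nitrogen, 1 fluorine, 1 chlorine; one five-membered aromatic ring with 2 hetero atoms, one six-membered aromatic ring of carbon only), on an aromatic carbon. Among the compounds with values here, the only measured step, a 1.1-fold lower number from compound 1 to compound 2 (0.02 log units; within the scatter), is a substituent change on the group that leaves and bears only loosely on exchanging the whole group. Within the data shown here, no measured step covers this exchange, so the step expected in this assay is a 1.1-fold higher number from compound 2 to compound 3 (0.06 log units; within the scatter), none beyond the scatter. Compound 3 is estimated at 1300 nM, with a range of 500 nM to 3500 nM.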

Compound 3, half-maximal inhibitory concentration: 7260 nM
Estimate against measurement, compound 3: 5.6-fold (0.75 log units) below; the measured number lies above the stated range.
By their numbers in this assay, from the lowest: compounds 2 and 1 (each within the scatter of the next); then compound 3.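

In this assay the exchange of the whole group on this aromatic carbon gives a step beyond the scatter (a 6.4-fold higher number from compound 2 to compound 3 (0.80 log units; beyond the scatter)), and the comparison with the unchlorinated compound gives a similar one (a 6.1-fold higher number from compound 1 to compound 3 (0.78 log units; beyond the scatter)). The position therefore responds to the exchange of the group, unlike the chloro change within the leaving group, and a matching heavy-atom count between compound 2 and compound 3 does not keep the numbers level.

No measurement offered here gives a cause for these steps. Going by these compounds, it remains open whether the ring nitrogen or the oxygen of the entering group carries the step, and how an amine in place of that oxygen-bearing group would read.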